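Swapping the Group on the Carbonyl of Compound 2

A few compounds are considered here, and "the series" means these few. Any claim that something is new, unique, unknown or untested is made for them only; others in the source may bear on it.

In a functional assay on Caco-2 cells (Homo sapiens) for antiproliferative activity, read by MTT assay, with a stated time of 48 h (a higher number here means a weaker inhibitor, a lower number a stronger inhibitor), compound 1 `CCn1c(C(=O)NCCCN(C)C)ccc1C(CC)(CC)c1ccc(OCCC(O)(CC)CC)c(C)c1` gives 490 nM. In this assay compound 2 `CCn1c(C(=O)N(CCC#N)CCC#N)ccc1C(CC)(CC)c1ccc(OCCC(O)(CC)CC)c(C)c1` gives > 50000 nM, which is a limit of the assay and not a number. That places compound 2 at the limit of > 50000 nM in this assay, at which 1 of the 2 values shown sits, so its true position is not known.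

The next compound, compound 3 `C#CC(C)OC(=O)c1ccc(C(CC)(CC)c2ccc(OCCC(O)(CC)CC)c(C)c2)n1CC`, has not yet been measured. It differs from compound 2 by a group of 5 heavy atoms (4 carbon, 1 oxygen; no ring) in place of a group of 9 heavy atoms (6 carbon, 3 nitrogen; no ring), on a carbonyl carbon: the (1-methylprop-2-yn-1-yl)oxy group enters on a carbonyl carbon whose other neighbour is an aromatic carbon.

Among the measured compounds shown here, only one measured step bears on this change, and it is large: an at least 100-fold higher number from compound 1 to compound 2 (2.00 log units; beyond the scatter). That step was made on the same carbonyl carbon, so it shows that a swap there can shift the number a long way. Compound 3 carries neither of the two groups measured so far, however, so the guide is a loose one.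

A modest move toward a lower number is expected in this assay, and a result at the limit remains quite possible. The expected change is an at least 4.1-fold lower number from compound 2 to compound 3 (0.61 log units; beyond the scatter), an estimate reckoned from a limit. The estimated value for compound 3 is 12000 nM, with an expected range from 2000 nM to 50000 nM.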

Compound 3, half-maximal inhibitory concentration: > 50000 nM
Compound 3: only a limit was reported; the forecaster's own chance of this, stated with the estimate: 35%; at least 4.1-fold (0.61 log units) between middle value and limit.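

Putting (1-methylprop-2-yn-1-yl)oxy in place of (3-(dimethylamino)propyl)amino on the carbonyl carbon brings an at least 100-fold higher number from compound 1 to compound 3 (2.00 log units; beyond the scatter), a large step of the same printed size as an at least 100-fold higher number from compound 1 to compound 2 (2.00 log units; beyond the scatter). The values of compound 2 and compound 3 are both limits and not numbers, so the step between them cannot be read. With compound 3, two unlike groups on this carbonyl carbon have reached the limit, and among the compounds shown only compound 1, with its (3-(dimethylamino)propyl)amino group, keeps a readable number: the limit of > 50000 nM in this assay, at which 2 of the 3 values shown sit.

Going by these compounds, how far compound 2 and compound 3 lie past the limit remains unknown, so the two cannot be ranked against each other. On these data alone, it also remains open which part of the (3-(dimethylamino)propyl)amino group goes with the readable value of compound 1, and whether a shorter amine chain, a longer amine chain or a carboxylic acid on this carbonyl carbon would give a number in this assay.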